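From ethoxy to chloro on the shared core

The compounds below may be only part of what the source reports. "The series", "measured", "known", "first", "only" and "open" are said of these compounds alone.

In a functional assay on A549 cells (Homo sapiens) for antiproliferative activity, read by MTT assay, with a stated time of 48 h (on this read-out higher numbers stand for weaker inhibition of growth and lower numbers for stronger inhibition of growth), compound 1 (`COC(=O)N1N=C(c2ccccc2)CC1c1cc(OC)c(OC)c(OC)c1`) gives 2880 nM, and compound 2 (`COC(=O)N1N=C(c2cccc(OC)c2)CC1c1cc(OC)c(OC)c(OC)c1`) gives 2590 nM. Compound 3 (`CCOc1cccc(C2=NN(C(=O)OC)C(c3cc(OC)c(OC)c(OC)c3)C2)c1`) gives 5290 nM. It stands apart from only one of the others, with a 2.0-fold higher number from compound 2 to compound 3 (0.31 log units; beyond the scatter), against a 1.8-fold higher number from compound 1 to compound 3 (0.26 log units; within the scatter).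

Compound 4 (`COC(=O)N1N=C(c2cccc(Cl)c2)CC1c1cc(OC)c(OC)c(OC)c1`) carries chloro in place of ethoxy on an aromatic carbon. Within the data shown here, no chloro compound has been measured, so the expectation rests on the small steps among the three, chiefly a 1.1-fold lower number from compound 1 to compound 2 (0.05 log units; within the scatter). A modest fall in this assay, back towards compound 1 and compound 2, is therefore expected. The estimated change is a 1.8-fold lower number from compound 3 to compound 4 (0.25 log units; within the scatter). Compound 4 is expected at 3000 nM, within an estimated range of 1400 nM to 6000 nM.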

Compound 4, concentration for 50% growth inhibition: 340 nM
Beside the measured number, compound 4's estimate is 8.8-fold (0.95 log units) above it; the whole stated range lies above it.
By their numbers in this assay, from the lowest: compound 4; then compounds 2, 1 and 3 (each within the scatter of the next, the first and the last beyond it).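

In this assay, hydrogen, methoxy and ethoxy at this place on the aromatic ring had differed at most modestly, yet chloro brings a 16-fold lower number from compound 3 to compound 4 (1.19 log units; beyond the scatter), along with a 7.6-fold lower number from compound 2 to compound 4 (0.88 log units; beyond the scatter) and an 8.5-fold lower number from compound 1 to compound 4 (0.93 log units; beyond the scatter). Among these compounds, the gain therefore does not come merely from losing ethoxy, since hydrogen at this place gives no such number, and the position proves far more responsive than the earlier compounds suggested. Nothing available explains this gain. On these data alone, whether bromo, fluoro or trifluoromethyl would match chloro at this place remains open, as does the effect of an amine there.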